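The source may report more compounds than this note shows. Statements on the series, on what has been measured and on what is new or still open speak of the compounds shown alone.

Working notes on the series.

Compound 1 `Cc1nc(C(F)(F)F)ccc1C(=O)Nc1ccc(Cl)c(-c2nc3c(n2C)CCCC3)c1` in an assay on C3H 10T1/2 cells for inhibition of Sonic hedgehog protein (Mus musculus), read by a luciferase reporter (on this read-out lower numbers stand for stronger inhibition and higher numbers for weaker inhibition), gives 150 nM. Compound 2 `Cc1nc(C(F)(F)F)ccc1C(=O)Nc1ccc(Cl)c(-n2cccn2)c1` gives 450 nM in this assay, and the step of a 3.0-fold higher number from compound 1 to compound 2 (0.48 log units; beyond the scatter) concerns the aryl group on the aniline side of the shared amide core. Compound 3 `O=C(Nc1ccc(Cl)c(-c2ccccn2)c1)c1cccnc1` gives 600 nM in this assay. Its number is the highest of the three shown; the gap to compound 2 lies within the usual scatter, so no order between those two is claimed, while the gap to compound 1 lies beyond the scatter.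

Compound 4 `O=C(Nc1ccc(Cl)c(-c2ccccn2)c1)c1cccc(Cl)c1` differs from compound 3 on the acyl side only: 3-chlorophenyl in place of pyridin-3-yl on a carbonyl carbon. Within the data shown here, no measured step touches this side of the core. Among the measured compounds shown here, the single step, from compound 1 to compound 2, alters the group on the aniline side, and compound 2 and compound 3 differ in more than one place, so their values give no clean comparison either. For compound 4 the change is expected to give no step beyond the scatter in this assay, that is no change at the digits printed from compound 3 to compound 4 (within the scatter). Compound 4 is estimated at 600 nM, within 200 nM to 1800 nM.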

Compound 4, half-maximal inhibitory concentration: 1500 nM
Compound 4: the middle estimate sits 2.5-fold (0.40 log units) below what was measured; low and high end bracket the measured number.
By their numbers in this assay, from the lowest: compound 1; then compounds 2 and 3 (each within the scatter of the next); then compound 4.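

Among these compounds, the acyl side of the shared core now has its first measured step: in this assay the number moves by a 2.5-fold higher number from compound 3 to compound 4 (0.40 log units; beyond the scatter) when 3-chlorophenyl replaces pyridin-3-yl on a carbonyl carbon, so the aniline side is no longer the only place where a change is seen to matter. The exchange removes a ring nitrogen and its hydrogen-bond acceptor and adds a chlorine in one move, and this single pair cannot separate those two parts of the change. No measurement shown bears on why the number rises.

Going by these compounds, it remains open whether plain phenyl would read with pyridin-3-yl, with 3-chlorophenyl or with neither, which would show whether the ring nitrogen or the chlorine carries the step. On these data alone, it is also open whether a group such as an amine or a carboxylic acid on this ring would move the number further, and whether the same exchange gives a step of similar size on the aniline-side groups of compound 1 and compound 2.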